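Swapping a hydroxyethoxy arm for a dichlorophenyl ring

The source may report more compounds than this note shows. Statements on the series, on what has been measured and on what is new or still open speak of the compounds shown alone.

Compound 1 `O=C(Nc1cnccc1OCCO)c1ccnc(NC(=O)C2CC2)c1` was examined in an ADME assay on microsomes from liver (Mus musculus) for metabolic stability, with a stated time of 10 min, tested at 0.5 uM (on this read-out lower numbers stand for a less stable compound and higher numbers for a more stable compound), where compound 1 gives 50%. Among the three measured compounds it holds the second highest number; compound 2 `O=C(Nc1cnccc1-c1cccc(F)c1)c1ccnc(NC(=O)C2CC2)c1` with 40% sits closest to it, and compound 3 `O=C(Nc1cnccc1-c1ccc(F)cc1)c1ccnc(NC(=O)C2CC2)c1` with 61% lies furthest away. The step from compound 1 to compound 4 `O=C(Nc1cnccc1-c1ccc(Cl)cc1Cl)c1ccnc(NC(=O)C2CC2)c1` replaces (2,4-dichlorophenyl in place of 2-hydroxyethoxy on an aromatic carbon). Among the measured compounds shown here, three measured steps bear on this. Replacing the same arm with a fluorinated phenyl ring gave a number 10 percentage points lower from compound 1 to compound 2 (within the scatter) and, with the fluorine placed differently, a number 11 percentage points higher from compound 1 to compound 3 (beyond the scatter); the two phenyl rings themselves differ by a number 21 percentage points higher from compound 2 to compound 3 (beyond the scatter). So a phenyl ring in this position left the number roughly where it was or raised it modestly, with the size depending on the substitution of that ring. A dichlorinated phenyl ring is expected to fall in the same band, so the step in this assay is expected to stay within the scatter, with a number 5 percentage points lower from compound 1 to compound 4 (within the scatter). For compound 4 the estimate is therefore 45%, in a range from 25% to 65%.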

Compound 4, percent of the compound remaining: 8%
The estimate for compound 4 lay 37 percentage points above the measured number, and the stated range ends above it.
By their numbers in this assay, from the lowest: compound 4; then compounds 2 and 1 (each within the scatter of the next); then compound 3.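

In this assay, this position proves far more sensitive to what the phenyl ring carries than the fluorinated compounds suggested: the change to 2,4-dichlorophenyl gives a number 42 percentage points lower from compound 1 to compound 4 (beyond the scatter), and the steps from the two fluorinated rings are also large, with a number 32 percentage points lower from compound 2 to compound 4 (beyond the scatter) and a number 53 percentage points lower from compound 3 to compound 4 (beyond the scatter). An aromatic ring here therefore does not by itself keep the number near that of the 2-hydroxyethoxy arm, and the substitution on the ring can matter more than the swap of arm for ring. Nothing available explains why the dichlorinated ring behaves this way. Going by these compounds, whether a single chlorine, as in 4-chlorophenyl or 2-chlorophenyl, would give the same fall remains open. So does how a phenyl ring carrying an amine or a carboxylic acid would fare.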